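A few compounds are considered here, and "the series" means these few. Any claim that something is new, unique, unknown or untested is made for them only; others in the source may bear on it.

Measured so far in an assay on membranes from HEK293 cells for displacement of a labelled ligand from adenosine receptor A2b (Homo sapiens), read by scintillation counting, with a stated time of 30 min, tested at 1 uM; on this read-out lower numbers stand for less inhibition and higher numbers for more inhibition at the one concentration tested (going by the name of the read-out):
compound 1 `CCCC(=O)C1=C(C)NC(=O)NC1c1ccoc1`: 22%
compound 2 `CCCC(=O)C1=C(C)NC(=O)NC1c1ccsc1`: 9%

Going by the values given here, compound 2 holds the lower of the two numbers; the one measured step, a number 13 percentage points lower from compound 1 to compound 2 (beyond the scatter), separates it from compound 1 and lies beyond the scatter.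

Compound 3 `CCSC(=O)C1=C(C)NC(=O)NC1c1ccsc1` follows from compound 2 by ethylsulfanyl in place of propyl on a carbonyl carbon. This exchange at the carbonyl carbon has no counterpart among the measured steps: the only step shown, a number 13 percentage points lower from compound 1 to compound 2 (beyond the scatter), concerns the ring on the saturated ring carbon and says nothing about replacing propyl with ethylsulfanyl. Among the compounds with values here, with no bearing step, the working expectation in this assay is a step that does not leave the scatter, so compound 3 is expected to sit near compound 2. Compound 3 is estimated at 10%, with a range from 0% to 25%. The step this estimate means, a number 1 percentage points higher from compound 2 to compound 3 (within the scatter), is expected to stay within the scatter.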

Compound 3, a percentage reported as inhibition, at one concentration (the size of the read-out at that concentration, not a potency): 17%
For compound 3 the middle estimate is 7 percentage points below the measured one; measured number inside the range.
By their numbers in this assay, from the lowest: compounds 2, 3 and 1 (each within the scatter of the next, the first and the last beyond it).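

The carbonyl carbon of the thiophen-3-yl compounds shows its first measured exchange in this assay: ethylsulfanyl in place of propyl gives a number 8 percentage points higher from compound 2 to compound 3 (within the scatter) and so is not separated from propyl at this position. Ethylsulfanyl brings in sulfur and a hydrogen-bond acceptor that propyl lacks, yet the numbers for the two groups stay within the scatter of each other on this background. No measurement is available that would explain this result. 

On these data alone, whether ethylsulfanyl gives a similar reading with the furan-3-yl ring of compound 1 remains open. Also open, as far as these compounds go, is what an ethoxy group, an amine or a longer chain on the same carbonyl carbon would give in this assay.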